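Ethoxy for fluoro in a thiazolidinedione series

The source may report more compounds than this note shows. Statements on the series, on what has been measured and on what is new or still open speak of the compounds shown alone.

Measured compounds:
compound 1 `C=CCOc1c(C)c(C)c2c(c1C)CCC(C)(COc1ccc(/C=C3\SC(=O)NC3=O)cc1OC)O2`: 1%
compound 2 `CC(C)=CCOc1c(C)c(C)c2c(c1C)CCC(C)(COc1ccc(/C=C3\SC(=O)NC3=O)cc1F)O2`: 64%

In a functional assay on MCF7 cells (Homo sapiens), tested at 7.5 uM (a lower number here means a stronger effect, a higher number a weaker effect of the compound at the concentration tested), compound 1 gives 1%. In this assay compound 2 gives 64%, the highest of the two numbers; its nearest neighbour, compound 1, lies lower by a gap beyond the scatter, so compound 2 is the weaker of the two at this concentration. Within the data shown here, the two differ in more than one place, so no single step is drawn between them.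

Compound 3 `CCOc1cc(/C=C2\SC(=O)NC2=O)ccc1OCC1(C)CCc2c(C)c(OCC=C(C)C)c(C)c(C)c2O1` has not yet been tested in this assay. It differs from compound 2 in one place: ethoxy in place of fluoro on an aromatic carbon. Among the measured compounds shown here, with no measured step of this kind to lean on, a step of moderate size is expected, toward a lower number, so that compound 3 is estimated at 35% with a range of 5% to 70%. The expected step from compound 2 to compound 3 is a number 29 percentage points lower from compound 2 to compound 3 (beyond the scatter).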

Compound 3, a percentage reported as activity, at one concentration (the size of the read-out at that concentration, not a potency): 54%
The estimate for compound 3 lay 19 percentage points below the measured number; low and high end bracket the measured number.
By their numbers in this assay, from the lowest: compound 1; then compounds 3 and 2 (each within the scatter of the next).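

In this assay, among these compounds, the single swap of ethoxy in place of fluoro, on an aromatic carbon ortho to a large group, amounts to a number 10 percentage points lower from compound 2 to compound 3 (within the scatter) and so leaves the two compounds indistinguishable. Among the compounds shown here, this is the first one-place comparison, and it shows that this position accepts ethoxy, with three heavy atoms and one hydrogen-bond acceptor, in place of the single fluorine without a step beyond the scatter. Nothing at hand explains this result.

From the compounds shown here alone, what remains open is whether this tolerance extends to other groups at this position, such as an amine, a carboxylic acid or a longer alkoxy chain. Also open is which of its differences from compound 3 accounts for the value of compound 1 at 1% in this assay, since those two compounds differ in more than one place.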